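Chloro to fluoro exchange on two related cores

The source may hold more compounds than are shown below. What is called first, only, known or untested is meant among the compounds shown, and "the series" means these compounds.

Measured compounds:
compound 1 `Cc1ccc(Cn2c(/C=C3\SC(=S)N(CC(=O)O)C3=O)nc3cc(Cl)ccc32)cc1`: 13700 nM
compound 2 `Cc1ccc(Cn2c(/C=C3\SC(=S)N(CC(=O)O)C3=O)nc3cc(F)ccc32)cc1`: 6550 nM
compound 3 `O=C(O)CN1C(=O)/C(=C/c2nc3ccc(Cl)cc3n2Cc2ccccc2F)SC1=S`: 9570 nM

All three were run in a functional assay on MDA-MB-231 cells (Homo sapiens) for cytotoxicity, read by MTT assay, with a stated time of 48 h; on this read-out higher numbers stand for weaker inhibition and lower numbers for stronger inhibition. For the measured compounds named here, the only counted change between compound 1 and compound 2 is fluoro in place of chloro on an aromatic carbon, and it gave a 2.1-fold lower number from compound 1 to compound 2 (0.32 log units; beyond the scatter). Compound 3 carries a different core from compound 1; how the two cores differ is not broken down here, and the two values sit within the scatter of each other, as do those of compound 3 and compound 2.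

Compound 4 `O=C(O)CN1C(=O)/C(=C/c2nc3ccc(F)cc3n2Cc2ccccc2F)SC1=S` has not yet been measured in this assay. Going by the values given here, it differs from compound 3 by fluoro in place of chloro on an aromatic carbon, the same change, at the same kind of place, as the one made from compound 1 to compound 2. On the strength of a 2.1-fold lower number from compound 1 to compound 2 (0.32 log units; beyond the scatter), a step of similar size is expected for compound 4, namely a 1.9-fold lower number from compound 3 to compound 4 (0.28 log units; within the scatter). One occurrence of the change is a thin base, so the range is kept wide. Compound 4 is therefore estimated at 5000 nM in this assay, expected to fall between 2500 nM and 10000 nM.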

Compound 4, half-maximal inhibitory concentration: > 50000 nM
Compound 4: no number, only a limit; the forecaster's own chance of this, stated with the estimate: 5%; at least 10-fold (1.00 log units) between middle value and limit.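

In this assay, fluoro in place of chloro on an aromatic carbon gave an at least 5.2-fold higher number from compound 3 to compound 4 (0.71 log units; beyond the scatter), so the step seen on the core of compound 1 did not carry over to the core of compound 3: the same change on two cores in this assay, a 2.1-fold lower number (0.32 log units; beyond the scatter) from compound 1 to compound 2 and an at least 5.2-fold higher number (0.71 log units; beyond the scatter) from compound 3 to compound 4, at least 10-fold (1.03 log units) apart, beyond the scatter of two such steps

Compound 4 gives > 50000 nM, which is a limit of the assay and not a number, so the size of this step remains open: the limit of > 50000 nM in this assay, at which 1 of the 4 values shown sits.

The two pairs show that this exchange cannot be treated as a fixed step across these two cores, but they do not show which feature of the cores separates the outcomes, and one pair per core gives no rule for either core.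

From the compounds shown here alone, it remains open whether bromo, methoxy or plain hydrogen on the same aromatic carbon would give a measurable value on the core of compound 3. Going by these compounds, it also remains open whether the same groups on the core of compound 1 would follow the order seen there for chloro and fluoro.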